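The source may hold more compounds than are shown below. What is called first, only, known or untested is meant among the compounds shown, and "the series" means these compounds.

Working notes on the series. In a functional assay on SNU-638 cells (Homo sapiens) for cytotoxicity, read by MTT assay (on this read-out lower numbers stand for stronger inhibition and higher numbers for weaker inhibition), compound 1 `COc1ccc(C(=O)/C=C/c2ccc(F)cc2)c(O)c1` gives 18400 nM. Compound 2 `COc1ccc(/C=C/C(=O)c2ccco2)cc1Br` gives 4290 nM in this assay, the lowest of the two numbers, with compound 1 the nearest and that gap beyond the scatter. Compound 3 `COc1ccc(/C=C/C(=O)c2cccs2)cc1Br` is not yet measured; it differs from compound 2 by thiophen-2-yl in place of furan-2-yl on a carbonyl carbon. Thiophen-2-yl in place of furan-2-yl on a carbonyl carbon is expected to move the number only a little, if anything toward a lower value, a step of a 1.3-fold lower number from compound 2 to compound 3 (0.13 log units; within the scatter) that is expected to stay close to the scatter. For compound 3 the expected value in this assay is 3200 nM, within 1200 nM to 8500 nM.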

Compound 3, half-maximal inhibitory concentration: 16600 nM
The estimate for compound 3 lay 5.2-fold (0.71 log units) below the measured number, and the stated range ends below it.
By their numbers in this assay, from the lowest: compound 2; then compounds 3 and 1 (each within the scatter of the next).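

In this assay the group on the carbonyl carbon is not a silent place: thiophen-2-yl in place of furan-2-yl gives a 3.9-fold higher number from compound 2 to compound 3 (0.59 log units; beyond the scatter) although both groups match in heavy-atom count, ring size, hydrogen-bond counts and charge. Sulfur for oxygen in the ring is thus enough to shift the number, with furan-2-yl the better of this pair. Nothing at hand accounts for the step.

On these data alone, how phenyl or pyridin-2-yl on this carbonyl carbon would read remains open. So does whether the same exchange gives a similar step on another core.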